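The source may report more compounds than this note shows. Statements on the series, on what has been measured and on what is new or still open speak of the compounds shown alone.

Of the compounds shown here, three sharing one core have been measured in an assay on isolated protein for inhibition of Dihydrofolate reductase (Mus musculus); a lower number here means a less potent compound, a higher number a more potent compound, by a factor of ten per unit of this negative logarithm. Compound 1 `CC1(C)N=C(N)N=C(N)N1c1ccc(OCc2cccc(S(=O)(=O)F)c2)c(Cl)c1` gives 7.72 in this assay. Compound 3 `CC1(C)N=C(N)N=C(N)N1c1ccc(OCc2cccc(S(=O)(=O)F)c2Cl)c(Cl)c1` gives 7.49 in this assay. Compound 2 `CC1(C)N=C(N)N=C(N)N1c1ccc(CCCCc2cc(Cl)ccc2S(=O)(=O)F)c(Cl)c1` gives 7.06 in this assay, the lowest of the three numbers, and its gaps to compound 3 and to compound 1 are both beyond the usual scatter. How the core of compound 2 differs from that of compound 3 is not broken down here.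

One structural change appears twice among these compounds. Going from compound 3 to compound 1 the change is hydrogen in place of chloro on an aromatic carbon, and the step it made was a number 0.23 log units higher from compound 3 to compound 1 (within the scatter). Compound 4 `CC1(C)N=C(N)N=C(N)N1c1ccc(CCCCc2ccccc2S(=O)(=O)F)c(Cl)c1` has not yet been measured; it differs from compound 2 by hydrogen in place of chloro on an aromatic carbon. This is the same kind of change, but not the same one: in compound 3 the departing chloro sits ortho to a fluorosulfonyl group and ortho to a large group, whereas in compound 2 it sits meta to a large group and para to a fluorosulfonyl group.

Because the earlier step of a number 0.23 log units higher from compound 3 to compound 1 (within the scatter) stayed within the scatter, a step of similar small size is expected here, estimated as a number 0.19 log units higher from compound 2 to compound 4 (within the scatter). Starting from the value of compound 2, 7.06, compound 4 is therefore expected to give about 7.25 in this assay, most likely somewhere between 6.85 and 7.65.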

Compound 4, logarithm of the reciprocal of the active concentration, log(1/C): 7.77
Estimate against measurement, compound 4: 0.52 log units below, and the stated range ends below it.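

In this assay, putting hydrogen in place of the chloro on compound 2 gives a number 0.71 log units higher from compound 2 to compound 4 (beyond the scatter). Set beside the earlier example, the size of this step did not carry over from one core to the other: the same change on two cores in this assay, a number 0.23 log units higher (within the scatter) from compound 3 to compound 1 and a number 0.71 log units higher (beyond the scatter) from compound 2 to compound 4, 0.48 log units apart, beyond the scatter of two such steps So, in this small series, the step seen for a change on one core is a poor guide to the size of the same kind of change on another core, but this does not show what lies behind the difference, as the two pairs differ both in their cores and in where the departing chloro sits, and two pairs cannot separate these two differences.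

Going by these compounds, it remains open whether the larger step belongs to the core or to the place of the chloro, a question that a pair carrying the chloro at the same place on both cores could answer. Also open, on these data alone, is whether a methyl or a methoxy group at the place meta to a large group and para to a fluorosulfonyl group would give a number closer to that of compound 2 or to that of compound 4.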